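Opening a lactone ring: from compound 3 to compound 4

This account rests on a few compounds, and the source may have more. Where it says the series, first, only, none or still open, it means among the compounds named here.

Measured so far in an assay on microsomes from liver for inhibition of sterol O-acyltransferase 1 (Rattus norvegicus); on this read-out lower numbers stand for stronger inhibition and higher numbers for weaker inhibition:
compound 1 `C[C@@]1(O)CC(=O)OC(CSc2nc(-c3cccc(Cl)c3)c(-c3cccc(Cl)c3)[nH]2)C1` gives 110 nM
compound 2 `CO[C@]1(C)C[C@H](O)C[C@@H](CSc2nc(-c3ccccc3)c(-c3ccccc3)[nH]2)O1` gives 30 nM
compound 3 `O=C1CC(O)CC(CSc2nc(-c3ccccc3)c(-c3ccccc3)[nH]2)O1` gives 910 nM

Among these three, compound 3 stands at the highest number, that is, the weakest inhibition; compound 1 comes nearer to it and compound 2 lies furthest away, both gaps beyond the usual scatter. Compound 4 `CCOC(CCSc1nc(-c2ccccc2)c(-c2ccccc2)[nH]1)OCC` keeps the shared core and differs from compound 3 only in a group of 8 heavy atoms (6 carbon, 2 oxygen; no ring) in place of a group of 8 heavy atoms (5 carbon, 3 oxygen; one six-membered non-aromatic ring with 1 hetero atom), on a saturated chain carbon bound to a sulfur; the ring is opened and the hydroxyl donor is gone. Among the compounds with values here, no measured pair shows this kind of change, so the direction is uncertain. In this assay a small step from compound 3 to compound 4 is expected, a 1.3-fold lower number from compound 3 to compound 4 (0.11 log units; within the scatter), hardly beyond the scatter. Compound 4 is therefore estimated at 700 nM, within 200 nM to 2500 nM.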

Compound 4, half-maximal inhibitory concentration: 69 nM
Beside the measured number, compound 4's estimate is 10-fold (1.01 log units) above it; the whole stated range lies above it.
By their numbers in this assay, from the lowest: compound 2; then compounds 4 and 1 (each within the scatter of the next); then compound 3.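

In this assay, putting 2,2-diethoxyethyl on this saturated chain carbon bound to a sulfur gives a 13-fold lower number from compound 3 to compound 4 (1.12 log units; beyond the scatter). So at this position, inhibition does not depend on the six-membered ring or on a hydrogen-bond donor, and an open chain with no ring serves better than the group in compound 3. Nothing measured here explains the size of this step.

This single change removes the ring and the donor together, so their separate shares cannot be told apart. On these data alone, whether an amine or a carboxylic acid would be accepted on this carbon remains open.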